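Cyclopentenyl in place of isopropyl: the expected step

The source may hold more compounds than are shown below. What is called first, only, known or untested is meant among the compounds shown, and "the series" means these compounds.

Compound 1 `CC(C(=O)NCc1ccc(Cl)cc1)c1ccc(NS(C)(=O)=O)c(F)c1` gives 367 nM in a functional assay on CHO cells for antagonist activity at transient receptor potential cation channel subfamily V member 1 (Rattus norvegicus); a higher number here means a weaker inhibitor, a lower number a stronger inhibitor.
Compound 2 `CC(C)c1ccc(CNC(=O)C(C)c2ccc(NS(C)(=O)=O)c(F)c2)cc1` gives 144 nM in this assay.

Compound 2 holds the lowest of the two numbers; its nearest neighbour is compound 1, and the step of a 2.5-fold lower number from compound 1 to compound 2 (0.41 log units; beyond the scatter) lies beyond the scatter. Compound 3 `CC(C(=O)NCc1ccc(C2C=CCC2)cc1)c1ccc(NS(C)(=O)=O)c(F)c1` differs from compound 2 by cyclopent-2-en-1-yl in place of isopropyl on an aromatic carbon. For the measured compounds named here, only the step of a 2.5-fold lower number from compound 1 to compound 2 (0.41 log units; beyond the scatter) bears on this change, and it was modest. A further enlargement on the same aromatic carbon is therefore expected to give a small step downward or none beyond the scatter, a 1.4-fold lower number from compound 2 to compound 3 (0.16 log units; within the scatter). For compound 3 the estimate in this assay is 100 nM, with a range of 30 nM to 350 nM.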

Compound 3, inhibition constant: 15 nM
Compound 3: middle estimate off by 6.7-fold (0.82 log units), on the high side; the measured number lies below the stated range.
By their numbers in this assay, from the lowest: compound 3; then compound 2; then compound 1.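

At this aromatic carbon, para to a large group, the response in this assay to enlarging the substituent is not confined to the modest change seen earlier: cyclopent-2-en-1-yl in place of isopropyl gives a 9.6-fold lower number from compound 2 to compound 3 (0.98 log units; beyond the scatter). Set against chloro, the same group gives a 24-fold lower number from compound 1 to compound 3 (1.39 log units; beyond the scatter). No measurement here accounts for this gain.

The compounds shown leave open whether the ring or its double bond carries the gain, a question that cyclopentyl would address. On these data alone, how tert-butyl or phenyl would behave at this carbon also remains open.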